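Benzyl to furanylmethyl amide: expected cytotoxicity in the series

The compounds below may be only part of what the source reports. "The series", "measured", "known", "first", "only" and "open" are said of these compounds alone.

Going by the values given here, in an ADME assay on J774.1 cells (Mus musculus) for cytotoxicity, read by resazurin assay, with a stated time of 48 h (on this read-out higher numbers stand for weaker inhibition and lower numbers for stronger inhibition), compound 3 `CCCCn1cc(C(=O)NCc2ccccc2)c(=O)c2cc(F)c(N3CCC(C(N)=O)CC3)cc21` gives 47000 nM, the only number so far. Compound 1 `CCCCn1cc(C(=O)O)c(=O)c2cc(F)c(N3CCC(C(N)=O)CC3)cc21` gives > 100000 nM, which is a limit of the assay. Compound 2 `CCCCn1cc(C(=O)NCc2ccc(OC)c([N+](=O)[O-])c2)c(=O)c2cc(F)c(N3CCC(C(N)=O)CC3)cc21` gives > 100000 nM, again a limit.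

Compound 4 `CCCCn1cc(C(=O)NCc2ccco2)c(=O)c2cc(F)c(N3CCC(C(N)=O)CC3)cc21` carries the next change: furan-2-yl in place of phenyl on a saturated chain carbon bound to an amide-type nitrogen. In words, furan-2-yl stands in place of phenyl on a saturated chain carbon bound to an amide-type nitrogen.

Among the compounds with values here, two measured steps bear on this: an at least 2.1-fold lower number from compound 1 to compound 3 (0.32 log units; beyond the scatter) and an at least 2.1-fold lower number from compound 2 to compound 3 (0.32 log units; beyond the scatter). Both rest on (the limit of > 100000 nM in this assay, at which 2 of the 3 values shown sit), so each fixes only a smallest possible size. Only an at least 2.1-fold lower number from compound 2 to compound 3 (0.32 log units; beyond the scatter) changes the group at this same place, and it offers no measure of a furan-2-yl group. A modest move towards the limit remains possible, but no clear shift is expected. In this assay the expected step is a 1.3-fold higher number from compound 3 to compound 4 (0.11 log units; within the scatter), within the scatter. For compound 4 the estimated value is 60000 nM, with an expected range of 25000 nM to 100000 nM.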

Compound 4, half-maximal inhibitory concentration: 41400 nM
Beside the measured number, compound 4's estimate is 1.4-fold (0.16 log units) above it, within the range that was stated.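

In this assay, the step at this place reads a 1.1-fold lower number from compound 3 to compound 4 (0.06 log units; within the scatter), so furan-2-yl and phenyl on a saturated chain carbon bound to an amide-type nitrogen cannot be told apart here, despite the ring oxygen that enters. Compound 2 goes against any reading that the amide alone sets the number, with the step of an at least 2.4-fold lower number from compound 2 to compound 4 (0.38 log units; beyond the scatter), while hydroxy on a carbonyl carbon gives way to ((furan-2-yl)methyl)amino in the step of an at least 2.4-fold lower number from compound 1 to compound 4 (0.38 log units; beyond the scatter). These last two steps fix only a smallest possible size: the limit of > 100000 nM in this assay, at which 2 of the 4 values shown sit.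

As far as these compounds go, their true size stays open. Also open, from the compounds shown here alone, is how a thiophen-2-yl group, a saturated tetrahydrofuran-2-yl group or a longer chain carrying the furan-2-yl ring would read at this place.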